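Extending the chain on the aromatic nitrogen: compound 2 to compound 3

A few compounds are considered here, and "the series" means these few. Any claim that something is new, unique, unknown or untested is made for them only; others in the source may bear on it.

Compound 1 `COc1cc(OC)c2cc(-c3ccccc3)c(O)nc2c1` in a functional assay on PC-3 cells (Homo sapiens) for cytotoxicity, read by colorimetric assay and MTT assay (a higher number here means a weaker inhibitor, a lower number a stronger inhibitor), gives 10000 nM.
Compound 2 `COc1ccc(-c2cc3c(OC)cc(OC)cc3n(C)c2=O)cc1` in this assay gives 10000 nM.

Compound 2 stands level with compound 1 at the digits shown; the two values lie within the usual scatter, so nothing separates them. Compound 3 `COc1ccc(-c2cc3c(OC)cc(OC)cc3n(CC(=O)OCc3ccccc3)c2=O)cc1` is not yet measured. It differs from compound 2 by benzyloxycarbonyl in place of hydrogen on a saturated chain carbon bound to an aromatic nitrogen. Among the compounds with values here, no measured pair changes in this way, so there is no step to lean on. The expectation is a step from compound 2 to compound 3 of a 1.1-fold lower number from compound 2 to compound 3 (0.05 log units; within the scatter), that is, none beyond the scatter. For compound 3 the estimate in this assay is 9000 nM, expected between 3000 nM and 20000 nM.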

Compound 3, half-maximal inhibitory concentration: 10000 nM
The estimate for compound 3 lay 1.1-fold (0.05 log units) below the measured number, within the range that was stated.
By their numbers in this assay, from the lowest: compounds 1, 2 and 3 (each within the scatter of the next).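

In this assay, the first step read at this position, methyl to (benzyloxycarbonyl)methyl on the aromatic nitrogen, reads no change at the digits printed from compound 2 to compound 3 (within the scatter). The position therefore accepts benzyloxycarbonyl, with its 10 heavy atoms and six-membered aromatic ring, without separating compound 3 from compound 2 in this read-out. No supporting measurement bears on this result.

From the compounds shown here alone, whether a carboxylic acid or an amine at the end of this chain, or a longer chain, would separate from compound 2 remains open.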